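The source may report more compounds than this note shows. Statements on the series, on what has been measured and on what is new or still open speak of the compounds shown alone.

Measured compounds:
compound 1, `Cc1cccc(-n2nncc2CN2C(=O)C3(C(C#N)=C(N)Oc4c3c3nc5ccccc5nc3c3ccccc43)c3ccccc32)c1`: 39600 nM
compound 2, `Cc1ccc(C)c(-n2nncc2CN2C(=O)C3(C(C#N)=C(N)Oc4c3c3nc5ccccc5nc3c3ccccc43)c3ccccc32)c1`: a limit, > 50000 nM
compound 3, `N#CC1=C(N)Oc2c(N)cc3nc4ccccc4nc3c2C12C(=O)N(Cc1cnnn1-c1ccccc1Cl)c1ccccc12`: 29800 nM

In a functional assay on A549 cells (Homo sapiens) for antiproliferative activity, read by MTT assay, with a stated time of 48 h (a lower number here means a stronger inhibitor, a higher number a weaker inhibitor), compound 1 gives 39600 nM. For compound 2 this assay reports only a limit, > 50000 nM. Compound 3 gives 29800 nM in this assay, a number that sits close to that of compound 1, within the scatter. The value of compound 2 is a limit rather than a number (the limit of > 50000 nM in this assay, at which 1 of the 3 values shown sits).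

The step now followed leads from compound 3 to compound 4, `N#CC1=C(N)Oc2c(N)cc3nc4ccccc4nc3c2C12C(=O)N(Cc1cnnn1-c1ccc([N+](=O)[O-])cc1[N+](=O)[O-])c1ccccc12`. The change is 2,4-dinitrophenyl in place of 2-chlorophenyl on an aromatic nitrogen.

Only one measured step exists among these compounds, an at least 1.2-fold higher number from compound 1 to compound 2 (0.10 log units; that floor lies within the scatter), and it concerns a methyl in place of hydrogen on an aromatic carbon, not a group on the aromatic nitrogen of the five-membered ring. Going by the values given here, no measured step therefore bears directly on the exchange of 2-chlorophenyl for 2,4-dinitrophenyl. All three measured compounds sit in a narrow band of weak inhibition, so compound 4 is expected to stay in that band, with a 1.1-fold higher number from compound 3 to compound 4 (0.03 log units; within the scatter) expected to be no step beyond the scatter. Compound 4 is thus estimated to give 32000 nM in this assay, within the range 10000 nM to 100000 nM.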

Compound 4, half-maximal inhibitory concentration: > 50000 nM
Compound 4 ended at the assay's limit; the forecaster's own chance of this, stated with the estimate: 30%; middle value at least 1.5-fold (0.19 log units) from the limit.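

Going by these compounds alone, the exchange of 2-chlorophenyl for 2,4-dinitrophenyl gives the first reading at this aromatic nitrogen of the five-membered ring, and that reading is one-sided: in this assay the step is an at least 1.6-fold higher number from compound 3 to compound 4 (0.22 log units; that floor lies within the scatter). For compound 4, this assay reports only a limit, > 50000 nM. The 2,4-dinitrophenyl group therefore brought no lower number at this position, while whether it brought a real loss stays unread, and compound 4 now stands at the same ceiling as compound 2: the limit of > 50000 nM in this assay, at which 2 of the 4 values shown sit.

With a single step at this position, the compounds shown cannot separate the part played by the two nitro groups from the part played by the loss of the chlorine, nor can they show whether any group on this nitrogen moves the number beyond the scatter. As far as these compounds go, how a phenyl ring carrying an amine or a carboxylic acid, or a longer chain in place of the ring, would read here remains open.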